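Swapping a Methyl for a Sulfanyl on the Chain

The source may report more compounds than this note shows. Statements on the series, on what has been measured and on what is new or still open speak of the compounds shown alone.

Compound 1, `CCCc1ccc2nc(N)sc2c1`: 6 mg/kg
Compound 2, `Nc1nc2ccc(C(=O)C(F)(F)F)cc2s1`: a limit only, > 10 mg/kg
Compound 3, `CCCn1c(=N)sc2cc(OC(F)(F)F)ccc21`: 4.5 mg/kg

In a functional assay on the whole organism with Rattus norvegicus as the target (a lower number here means that less compound is needed, a higher number that more compound is needed for the effect), compound 3 has the lower of the two numbers, but compound 1 lies within the usual scatter of it. For compound 2 the assay reports only a limit, > 10 mg/kg, and not a number.

Compound 4, `N=c1sc2cc(OC(F)(F)F)ccc2n1CCS`, differs from compound 3 by sulfanyl in place of methyl on a saturated chain carbon, two bonds along the chain from an aromatic nitrogen. Within the data shown here, no measured pair shows this kind of change, so there is no step to lean on. Compound 4 is expected to stay close to compound 3, with a small rise in dose that may not exceed the scatter, a 1.3-fold higher number from compound 3 to compound 4 (0.12 log units; within the scatter). Compound 4 is estimated at 6 mg/kg, between 2.5 mg/kg and 15 mg/kg.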

Compound 4, dose for half-maximal effect: 2 mg/kg
Compound 4: middle estimate off by 3.0-fold (0.48 log units), on the high side; measured number outside the range, below it.
By their numbers in this assay, from the lowest: compound 4; then compounds 3 and 1 (each within the scatter of the next). At a limit, above all of these: compound 2.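

In this assay, among these compounds, sulfanyl in place of methyl on a saturated chain carbon, two bonds along the chain from an aromatic nitrogen, gives a 2.3-fold lower number from compound 3 to compound 4 (0.35 log units; beyond the scatter), the first step that can be read between two measured compounds. This chain position therefore responds to a change of a single heavy atom, modestly but beyond the scatter. Nothing measured here explains why the number falls.

Still open, from the compounds shown here alone, is whether a hydroxyl or an amine at this place would lower the number as well. Going by these compounds, it is also open whether a longer chain carrying the sulfanyl would keep the lower number.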